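The compounds below may be only part of what the source reports. "The series", "measured", "known", "first", "only" and "open" are said of these compounds alone.

Measured compounds:
- Compound 1, `O=C(CN1CCN(c2ccccc2)CC1)N1CCN(c2nnc(-c3ccccc3)c(-c3ccccc3)n2)CC1`: in a functional assay on MCF7 cells (Homo sapiens) for cytotoxicity, read by MTT assay, with a stated time of 24 h (a lower number here means a stronger inhibitor, a higher number a weaker inhibitor), compound 1 gives > 963000 nM, which is a limit of the assay and not a number.
- Compound 2, `COc1ccccc1N1CCN(CC(=O)N2CCN(c3nnc(-c4ccc(C)cc4)c(-c4ccc(C)cc4)n3)CC2)CC1`: in this assay compound 2 gives 59400 nM.
- Compound 3, `COc1ccc(-c2nnc(N3CCN(C(=O)CN4CCN(c5ccccc5)CC4)CC3)nc2-c2ccc(OC)cc2)cc1`: in this assay compound 3 gives > 863000 nM, again a limit and not a number.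

Going by the values given here, of the three results, two are limits, so compound 3 stands where compound 1 stands, at the edge of what this assay can report (the limit of > 863000 nM in this assay, at which 1 of the 3 values shown sits, (the limit of > 963000 nM in this assay, at which 1 of the 3 values shown sits)), while compound 2 is the only one with a measured number.

Compound 4, `COc1ccc(-c2nnc(N3CCN(C(=O)CN4CCN(c5ccc(OC)cc5)CC4)CC3)nc2-c2ccc(OC)cc2)cc1`, differs from compound 3 in one place: methoxy in place of hydrogen on an aromatic carbon. The change sits on the phenyl carried by the piperazine at the far end of the amide, and the rest of the molecule, including the two methoxy-bearing rings on the shared core, stays as in compound 3.

Among the compounds with values here, no measured pair in this set isolates this change, so the expectation rests on compound 3 alone. Since compound 3 gives only a limit, the most likely outcome for compound 4 is a value still close to or beyond that edge; the expected step from compound 3 to compound 4 is an at least 1.7-fold lower number from compound 3 to compound 4 (0.23 log units; that floor lies within the scatter), no more than the scatter. The estimate for compound 4 in this assay is 500000 nM, within 80000 nM to 1000000 nM.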

Compound 4, half-maximal inhibitory concentration: > 821000 nM
Compound 4 was reported as a limit; the forecaster's own chance of this, stated with the estimate: 60%; at least 1.6-fold (0.21 log units) between middle value and limit.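

In this assay, going by these compounds alone, compound 3 and compound 4 are both reported as limits and not as numbers, so no step between them can be read. The compounds shown leave open whether the change from phenyl to 4-methoxyphenyl would move the result in this assay for a compound that gives a measured number.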